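Trimming the isopropyl amide of compound 1 to ethyl

The compounds below may be only part of what the source reports. "The series", "measured", "known", "first", "only" and "open" are said of these compounds alone.

Compound 1 `CC(C)NC(=O)[C@H]1CC[C@@H](n2/c(=N/C(=O)c3ccccc3)[nH]c3ccc(CN4CCCCC4)cc32)CC1` gives 389 mL.min-1.g-1
Compound 2 `CC(C)NC(=O)[C@H]1CC[C@@H](n2/c(=N/C(=O)c3cc(F)cc(Cl)c3)[nH]c3ccc(CN4CCC(C(C)(C)O)CC4)cc32)CC1` gives 43 mL.min-1.g-1
Compound 3 `CC(C)NC(=O)[C@H]1CC[C@@H](n2/c(=N/C(=O)c3ccc(F)cc3)[nH]c3ccc(CN4CCCCC4)cc32)CC1` gives 451 mL.min-1.g-1

These numbers come from an in vitro ADME assay on microsomes from liver (Rattus norvegicus) for metabolic stability; a lower number here means slower removal, a higher number faster removal of the compound. Compound 1 sits level with compound 3, within the scatter, while compound 2 has a much lower number, a gap beyond the scatter. Compound 4 `CCNC(=O)[C@H]1CC[C@@H](n2/c(=N/C(=O)c3ccccc3)[nH]c3ccc(CN4CCCCC4)cc32)CC1` still awaits measurement. It differs from compound 1 in one place, where isopropylcarbamoyl becomes ethylcarbamoyl: hydrogen in place of methyl on a saturated chain carbon bound to an amide-type nitrogen and a saturated chain carbon.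

Among the measured compounds shown here, no measured step touches this group. For the measured compounds named here, the only measured step confined to one place is a 1.2-fold higher number from compound 1 to compound 3 (0.06 log units; within the scatter), for fluoro in place of hydrogen on an aromatic carbon. It is a different change and offers only a weak guide. Compound 2 differs from compound 1 in more than one place, so its low number says nothing about this change. A small change is therefore expected, with no clear direction. The expected step is a 1.1-fold lower number from compound 1 to compound 4 (0.06 log units; within the scatter), which would lie within the scatter. For compound 4 the estimate is 340 mL.min-1.g-1, with an expected range of 180 mL.min-1.g-1 to 640 mL.min-1.g-1.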

Compound 4, intrinsic clearance in microsomes: 310 mL.min-1.g-1
Estimate against measurement, compound 4: 1.1-fold (0.04 log units) above; the range from low to high includes it.
By their numbers in this assay, from the lowest: compound 2; then compounds 4, 1 and 3 (each within the scatter of the next).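

In this assay, among the compounds shown here, the first single-place step at this position, from isopropylcarbamoyl to ethylcarbamoyl, gives a 1.3-fold lower number from compound 1 to compound 4 (0.10 log units; within the scatter). Compound 1 and compound 4 therefore stand level: on the core of compound 1, taking one methyl off the isopropyl group does not move the number past the usual variation between repeat measurements. Nothing available here gives a reason for this result.

Still open, as far as these compounds go, is whether a bigger change at this position, such as a carboxylic acid in place of the amide or a longer chain such as butyl on the amide nitrogen, would shift the number beyond the scatter. From the compounds shown here alone, it is also open whether trimming isopropyl to ethyl would act the same way with the other groups that compound 2 carries.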